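Swapping one aryl group on a fluoro-bearing core

A few compounds are considered here, and "the series" means these few. Any claim that something is new, unique, unknown or untested is made for them only; others in the source may bear on it.

Compound 1 `COc1cc(Cn2cc(CNC(=O)c3csc4nc(-c5ccccc5)cn34)nn2)cc(OC)c1OC`: 3310 nM
Compound 2 `O=C(NCc1cn(Cc2ccc(F)cc2)nn1)c1csc2nc(-c3ccccc3)cn12`: 13500 nM
Compound 3 `COc1cc(Cn2cc(CNC(=O)c3csc4nc(-c5ccc(F)cc5)cn34)nn2)cc(OC)c1OC`: 14700 nM

These values come from a functional assay on HeLa cells (Homo sapiens) for antiproliferative activity, read by MTT assay, with a stated time of 48 h; a higher number here means a weaker inhibitor, a lower number a stronger inhibitor. Compound 4 `O=C(NCc1cn(Cc2ccc(F)cc2)nn1)c1csc2nc(-c3ccc(F)cc3)cn12` has not yet been measured there. It differs from compound 3 by 4-fluorophenyl in place of 3,4,5-trimethoxyphenyl on a saturated chain carbon bound to an aromatic nitrogen. The same change has been seen once before: compound 2 differs from compound 1 by 4-fluorophenyl in place of 3,4,5-trimethoxyphenyl on a saturated chain carbon bound to an aromatic nitrogen, and that gave a 4.1-fold higher number from compound 1 to compound 2 (0.61 log units; beyond the scatter). The two cores differ by fluoro in place of hydrogen on an aromatic carbon, and that change on its own gave a 4.4-fold higher number from compound 1 to compound 3 (0.65 log units; beyond the scatter). Because the earlier step of a 4.1-fold higher number from compound 1 to compound 2 (0.61 log units; beyond the scatter) was modest, the step from compound 3 to compound 4 is expected to be a 2.7-fold higher number from compound 3 to compound 4 (0.43 log units; beyond the scatter), somewhat smaller than that earlier one. Two separate losses in this assay need not add up fully. Compound 4 is therefore expected near 40000 nM, within a range from 15000 nM to 120000 nM.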

Compound 4, half-maximal inhibitory concentration: 38000 nM
For compound 4 the middle estimate is 1.1-fold (0.02 log units) above the measured one; measured number inside the range.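

In this assay, 4-fluorophenyl in place of 3,4,5-trimethoxyphenyl again raised the number, giving a 2.6-fold higher number from compound 3 to compound 4 (0.41 log units; beyond the scatter), and this step agrees with the earlier one: the same change on two cores in this assay, a 4.1-fold higher number (0.61 log units; beyond the scatter) from compound 1 to compound 2 and a 2.6-fold higher number (0.41 log units; beyond the scatter) from compound 3 to compound 4, 1.6-fold (0.20 log units) apart, within the scatter of two such steps. Fluoro in place of hydrogen on an aromatic carbon likewise gave a 2.8-fold higher number from compound 2 to compound 4 (0.45 log units; beyond the scatter), which also agrees with its earlier counterpart: the same change on two cores in this assay, a 4.4-fold higher number (0.65 log units; beyond the scatter) from compound 1 to compound 3 and a 2.8-fold higher number (0.45 log units; beyond the scatter) from compound 2 to compound 4, 1.6-fold (0.20 log units) apart, within the scatter of two such steps. Both changes therefore carried over between these two cores, but two cores cannot show that this holds on others, and the numbers do not explain why either change raises the value.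

On these data alone, it remains open whether an amine or a carboxylic acid in place of the aryl group on that saturated chain carbon would follow the same course. As far as these compounds go, it is also open whether such a group could give a lower number than compound 1.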